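This account rests on a few compounds, and the source may have more. Where it says the series, first, only, none or still open, it means among the compounds named here.

Compound 1, `COc1ccc(OC(=O)Nc2ccc([Se]C#N)cc2)cc1`: 69600 nM
Compound 2, `CCCCOC(=O)Nc1ccc([Se][Se]c2ccc(NC(=O)OCCCC)cc2)cc1`: 82400 nM
Compound 3, `O=C(Nc1ccc([Se][Se]c2ccc(NC(=O)OCc3ccc([N+](=O)[O-])cc3)cc2)cc1)OCc1ccc([N+](=O)[O-])cc1`: 75900 nM

These three compounds were tested in a functional assay on HT-29 cells (Homo sapiens) for cytotoxicity, read by MTT assay, with a stated time of 72 h; a lower number here means that less compound is tolerated, a higher number that more compound is tolerated. Compound 1 gives 69600 nM, compound 2 gives 82400 nM and compound 3 gives 75900 nM. The three numbers sit close together: the gaps between compound 1 and each of the other two lie within the usual scatter of repeated measurements, so none of the three can be set apart from the others. Despite their different structures, the cells tolerate all three to a similar degree.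

Compound 4, `N#C[Se]c1ccc(NC(=O)Oc2ccccc2)cc1`, has not yet been measured in this assay. It differs from compound 1 in one place: hydrogen in place of methoxy on an aromatic carbon. Within the data shown here, no pair of measured compounds that differ in a single place is available, so this change cannot be checked against a measured step. Since compounds carrying quite different groups all fall within the scatter of one another, a change as small as this one is expected to move the number little, if at all. Compound 4 is therefore expected to give about 72000 nM, with a range from 36000 nM to 145000 nM. That estimate means a step of a 1.0-fold higher number from compound 1 to compound 4 (0.01 log units; within the scatter) that stays within the scatter.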

Compound 4, concentration lethal to 50% of the cells: 71700 nM
Beside the measured number, compound 4's estimate is 1.0-fold (0.00 log units) above it, and the stated range covers the measured number.
By their numbers in this assay, from the lowest: compounds 1, 4, 3 and 2 (each within the scatter of the next).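

In this assay, hydrogen in place of methoxy on an aromatic carbon, para to a large group, gives a 1.0-fold higher number from compound 1 to compound 4 (0.01 log units; within the scatter). Among these compounds, this is the first comparison here between two compounds that differ in only one place, so the close agreement can be tied to one specific change rather than to a general similarity among structures that differ in several places. At this position, the methoxy group and its one hydrogen-bond acceptor can be replaced by hydrogen without a change that can be told from the scatter, and no measurement available here explains this result.

On these data alone, only hydrogen and methoxy are compared at this position, so it remains open whether an amine, a carboxylic acid or a longer chain such as butoxy would also leave the number within the scatter. This single step also cannot show how the number responds to a change elsewhere in the core of compound 1, such as replacing the nitrile with a methyl group.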